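The source may hold more compounds than are shown below. What is called first, only, known or untested is meant among the compounds shown, and "the series" means these compounds.

Compound 1 `O=C(Nc1ccc(Nc2ncnc3c2OCCN3)cc1)Nc1ccc(C(F)(F)F)cc1` gives 10000 nM in a functional assay on BaF3 cells (Mus musculus) for inhibition, read by MTT assay, with a stated time of 3 days; a higher number here means a weaker inhibitor of growth, a lower number a stronger inhibitor of growth. Compound 2 `COc1cccc(NC(=O)Nc2ccc(Nc3ncnc4c3OCCN4)cc2)c1` reaches only a limit of this assay, > 10000 nM, which is not a number. The step of a number no lower from compound 1 to compound 2 (the limit leaves the size open) therefore cannot be sized, because of the limit of > 10000 nM in this assay, at which 1 of the 2 values shown sits. Compound 3 `CC(C)(C)c1cc(NC(=O)Nc2ccc(Nc3ncnc4c3OCCN4)cc2)no1` differs from compound 2 by 5-(tert-butyl)-1,2-oxazol-3-yl in place of 3-methoxyphenyl on an amide-type nitrogen. No measured step bears directly on this change, and the single step shown ends at a limit, so little can be drawn from it. The step of a number no higher from compound 2 to compound 3 (the limit leaves the size open) is expected to be none beyond the usual scatter. Compound 3 is estimated at 10000 nM, with a range from 3000 nM to 30000 nM.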

Compound 3, concentration for 50% growth inhibition: > 10000 nM
Compound 3 gave a limit, no number (the forecaster's own chance of this, stated with the estimate: 50%); the middle value sits exactly at the limit.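

In this assay compound 3 gives > 10000 nM, which is a limit of the assay and not a number. A five-membered aromatic ring with 2 hetero atoms in this place therefore gives no readable value, just as the six-membered ring of carbon only in compound 2 gave none. The data show a number no lower from compound 1 to compound 3 (the limit leaves the size open) and give no size for it. The step between compound 2 and compound 3 cannot be read, and the values now gather at one end of the scale: the limit of > 10000 nM in this assay, at which 2 of the 3 values shown sit.

As far as these compounds go, how far compound 2 and compound 3 actually lie from each other stays open. So does whether an amine, a carboxylic acid or a longer chain on this amide-type nitrogen would give a readable number.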